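The source may hold more compounds than are shown below. What is called first, only, known or untested is meant among the compounds shown, and "the series" means these compounds.

Working notes on the series. Compound 1 `CC(O)(CS(=O)(=O)c1ccc(Br)cc1)c1nc(-c2ccccc2)no1` carries an unsubstituted phenyl on the shared core. In a functional assay on DU-145 cells (Homo sapiens) for cytotoxicity, read by MTT assay (on this read-out lower numbers stand for stronger inhibition and higher numbers for weaker inhibition), compound 1 gives > 100000 nM, which is a limit of the assay. Compound 2 `CC(O)(CS(=O)(=O)c1ccc(Br)cc1)c1nc(-c2ccc(Cl)cc2)no1` adds a chloro on that phenyl. In this assay compound 2 gives > 100000 nM, again a limit. The step that the two limits leave unreadable from compound 1 to compound 2 cannot be read because both values sit at the limit of > 100000 nM in this assay, at which 3 of the 3 values shown sit. Compound 3 `CC(O)(CS(=O)(=O)c1ccccc1)c1nc(-c2ccc(F)c(Cl)c2)no1` pairs an unsubstituted sulfonylphenyl with a fluoro-chloro phenyl. In this assay compound 3 gives > 100000 nM, a limit only. Compound 3 therefore stands where compound 1 and compound 2 stand, with no number that would rank it against them.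

Compound 4 `CC(O)(CS(=O)(=O)c1ccc(Br)cc1)c1nc(-c2ccc(F)c(Cl)c2)no1` differs from compound 3 by bromo in place of hydrogen on an aromatic carbon. Among the compounds with values here, compound 1 and compound 2 already carry the 4-bromophenyl on the sulfonyl and give no number in this assay; no measured step reads this change. The expectation for compound 4 is thus a step that the limit leaves unreadable from compound 3 to compound 4 not beyond the scatter, most probably another limit. Compound 4 is estimated at 150000 nM, in the range 50000 nM to 500000 nM.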

Compound 4, half-maximal inhibitory concentration: 75000 nM
Compound 4: middle estimate off by 2.0-fold (0.30 log units), on the high side, and the stated range covers the measured number.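

Compound 4 is the only compound shown that gives a number in this assay, and it pairs the 4-bromophenyl with the 3-chloro-4-fluorophenyl on the shared core. Going from phenyl to 4-bromophenyl gives an at least 1.3-fold lower number from compound 3 to compound 4 (0.12 log units; that floor lies within the scatter), while the changes on the other aromatic ring give an at least 1.3-fold lower number from compound 2 to compound 4 (0.12 log units; that floor lies within the scatter) and an at least 1.3-fold lower number from compound 1 to compound 4 (0.12 log units; that floor lies within the scatter); none of these floors shows a change beyond the scatter. The full size of each step cannot be read, as the other compounds give only a limit: the limit of > 100000 nM in this assay, at which 3 of the 4 values shown sit.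

Going by these compounds, whether the bromo has any real effect on this read-out remains open, as does whether the same holds with 4-chlorophenyl or plain phenyl on the other side of the core. Also open, on these data alone, is how an amine or a carboxylic acid in place of the bromo would read in this assay.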